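The source may report more compounds than this note shows. Statements on the series, on what has been measured and on what is new or still open speak of the compounds shown alone.

Measured in an in vitro functional assay on cells for agonist activity at Bombesin receptor subtype-3 (Homo sapiens), read by luminescence and calcium flux; a higher number here means that more compound is needed for the effect, a lower number that less compound is needed:
compound 1 `COc1cccc(Cc2cnc(CCc3ccc(-c4ccccc4C(=O)O)cc3)[nH]2)c1`, 4120 nM
compound 2 `O=C(O)c1ccccc1-c1ccc(CCc2ncc(Cc3ccccc3Cl)[nH]2)cc1`, 292 nM
compound 3 `O=C(O)c1ccccc1-c1ccc(CCc2ncc(CCc3ccccc3)[nH]2)cc1`, 1320 nM

Compound 3 stands second highest of the three numbers; its nearest neighbour is compound 1, its furthest is compound 2. The step to compound 4 `N#Cc1cccc(Cc2cnc(CCc3ccc(-c4ccccc4C(=O)O)cc3)[nH]2)c1` is 3-cyanophenyl in place of benzyl on a saturated chain carbon bound to an aromatic carbon. Going by the values given here, two measured steps bear on it. Between compound 1 and compound 3, a 3.1-fold lower number from compound 1 to compound 3 (0.49 log units; beyond the scatter); compound 4 runs this exchange in the reverse direction, benzyl giving way to a substituted phenyl. Between compound 2 and compound 3, a 4.5-fold higher number from compound 2 to compound 3 (0.66 log units; beyond the scatter). On these numbers benzyl sits in the middle, and 3-cyanophenyl resembles the 3-methoxyphenyl of compound 1 more closely than the 2-chlorophenyl of compound 2, so a modest rise toward compound 1 is expected: a 2.0-fold higher number from compound 3 to compound 4 (0.29 log units; within the scatter). Compound 4 is therefore estimated at 2600 nM, with a range of 800 nM to 8000 nM.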

Compound 4, half-maximal effective concentration: 812 nM
Compound 4: the middle estimate sits 3.2-fold (0.51 log units) above what was measured; measured number inside the range.
By their numbers in this assay, from the lowest: compound 2; then compounds 4 and 3 (each within the scatter of the next); then compound 1.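

With the chain and the core held fixed, only the group on the aromatic carbon of the benzyl ring changes in this assay. Cyano in place of methoxy gives a 5.1-fold lower number from compound 1 to compound 4 (0.71 log units; beyond the scatter). The change from benzyl to 3-cyanophenyl does not separate the two, with a 1.6-fold lower number from compound 3 to compound 4 (0.21 log units; within the scatter). The 2-chlorophenyl of compound 2 keeps the lowest number, with a 2.8-fold higher number from compound 2 to compound 4 (0.44 log units; beyond the scatter).

No measurement here gives a cause for these steps. An amine or an amide in place of the cyano remains an open test of this aromatic carbon.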